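The source may report more compounds than this note shows. Statements on the series, on what has been measured and on what is new or still open speak of the compounds shown alone.

In a functional assay on HCT-116 cells (Homo sapiens) for cytotoxicity, read by MTT assay, with a stated time of 48 h, in the presence of a further agent that is not named here (a lower number here means that less compound is needed, a higher number that more compound is needed for the effect), compound 1 `Cc1nn(C)c2nc(NNC(=O)Nc3cc(Cl)nc(Cl)c3)cc(C3CC3)c12` gives 67700 nM. This stands within the scatter of compound 3 `COc1ccc(-c2cc(NNC(=O)Nc3cc(Br)nc(Br)c3)nc3c2cnn3C)cc1`, at 45200 nM. Compound 2 `Cn1ncc2c(-c3ccccc3)cc(NNC(=O)Nc3cc(Cl)nc(Cl)c3)nc21`, at 6240 nM, shows a lower number, and that gap from compound 1 lies beyond the scatter.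

Compound 4 `Cc1nn(C)c2nc(NNC(=O)Nc3cc(Cl)nc(Cl)c3)cc(-c3ccc(Cl)s3)c12` carries 5-chlorothiophen-2-yl in place of cyclopropyl on an aromatic carbon of the shared core: 5-chlorothiophen-2-yl in place of cyclopropyl on an aromatic carbon. For the measured compounds named here, no pair of measured compounds isolates this change, so any expectation rests on indirect evidence. Compound 2 also has an aromatic ring on that carbon and gives 6240 nM, which suggests that the number may fall. Compound 3 has an aromatic ring there too, yet it gives 45200 nM and so goes against that suggestion, although it differs from compound 2 in other places as well.

A moderate move towards a lower number is therefore expected, with the estimated step being a 4.2-fold lower number from compound 1 to compound 4 (0.63 log units; beyond the scatter). For compound 4 the estimated value is 16000 nM, with an expected range from 4000 nM to 60000 nM.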

Compound 4, half-maximal effective concentration: 42100 nM
Estimate against measurement, compound 4: 2.6-fold (0.42 log units) below; low and high end bracket the measured number.
By their numbers in this assay, from the lowest: compound 2; then compounds 4, 3 and 1 (each within the scatter of the next).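

In this assay, for the compounds shown here, 5-chlorothiophen-2-yl in place of cyclopropyl on this aromatic carbon gives a 1.6-fold lower number from compound 1 to compound 4 (0.21 log units; within the scatter), the first step at this position that can be read from a single change. Within the compounds shown, this exchange of a three-membered non-aromatic ring of carbon for a larger five-membered aromatic ring with 1 hetero atom therefore leaves the number within the scatter, so this carbon takes either group with no clear change in this assay. Nothing measured here accounts for this result.

As far as these compounds go, whether a group of another kind on this carbon, such as an amine, a carboxylic acid or a longer alkyl chain, would move the number beyond the scatter remains open. Also open, from the compounds shown here alone, is whether the same exchange would give a similar step with bromine in place of the chlorines on the dihalogenated ring.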